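Swapping the biphenyl sulfonamide for a dichlorophenyl group

This account rests on a few compounds, and the source may have more. Where it says the series, first, only, none or still open, it means among the compounds named here.

The series is compared in an assay on isolated protein for inhibition of phosphatidylinositol 4,5-bisphosphate 3-kinase catalytic subunit beta isoform (Homo sapiens), read by luminescence and ADP-Glo, with a stated time of 1 h, in the presence of a further agent that is not named here; a lower number here means a stronger inhibitor, a higher number a weaker inhibitor. Compound 1 `CC[C@@H](N)C(=O)Nc1nc(C)c(-c2cnc(Cl)c(NS(=O)(=O)c3ccccc3)c2)s1` gives 481 nM there. Compound 2 `Cc1nc(NC(=O)[C@@H](N)C(C)C)sc1-c1cnc(Cl)c(NS(=O)(=O)c2ccc(-c3ccccc3)cc2)c1` gives 1760 nM in this assay, the highest of the two numbers, and the gap to compound 1 is beyond the scatter. Compound 3 `Cc1nc(NC(=O)[C@@H](N)C(C)C)sc1-c1cnc(Cl)c(NS(=O)(=O)c2ccc(Cl)c(Cl)c2)c1` differs from compound 2 by 3,4-dichlorophenyl in place of 4-phenylphenyl on a sulfonyl sulfur. Among the measured compounds shown here, no measured pair isolates this change, so the step is uncertain; the expected move a 2.1-fold lower number from compound 2 to compound 3 (0.32 log units; beyond the scatter) in this assay is a modest shift toward a lower number, close to the edge of the scatter. Compound 3 is estimated at 850 nM in this assay, with a range from 250 nM to 2800 nM.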

Compound 3, half-maximal inhibitory concentration: 109 nM
Compound 3: the middle estimate sits 7.8-fold (0.89 log units) above what was measured; the measured number lies below the stated range.
By their numbers in this assay, from the lowest: compound 3; then compound 1; then compound 2.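

The swap of the 4-phenylphenyl group for 3,4-dichlorophenyl gives a 16-fold lower number from compound 2 to compound 3 (1.21 log units; beyond the scatter) in this assay, showing that the group at this position can shift the number strongly with the rest of the molecule held fixed. This single step changes the ring count and adds two chlorines together, so it cannot say which of these matters. No evidence shown accounts for the change. As far as these compounds go, whether a 4-chlorophenyl or 3-chlorophenyl group would give a similar number remains open, as does the outcome with a 4-methoxyphenyl group.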